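The compounds below may be only part of what the source reports. "The series", "measured", "known", "first", "only" and "open" are said of these compounds alone.

Measured so far in an assay on isolated protein for inhibition of Trypsin (Homo sapiens), read by fluorescence, with a stated time of 15 min, tested at 50 uM; on this read-out higher numbers stand for more inhibition at the one concentration tested (going by the name of the read-out) and lower numbers for less inhibition:
- compound 1, `N=C(N)Nc1ccc(OC(=O)c2ccc(N)cc2)cc1`: 101%
- compound 2, `N=C(N)NCCCCOC(=O)c1ccc(NC(=N)N)cc1`: 84%
- compound 3, `N=C(N)NCCCC(=O)Oc1ccc(NC(=N)N)cc1`: 18.3%

Compound 3 stands lowest of the three numbers. Its nearest neighbour is compound 2, whose number is higher by a margin beyond the scatter; the furthest is compound 1, higher still, again beyond the scatter. For the measured compounds named here, no pair here differs in only one place, so no single-point step is available to lean on.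

Compound 4, `N=C(N)NCCCCC(=O)Oc1ccc(NC(=N)N)cc1`, is not yet measured. It differs from compound 3 in one place: a group of 5 heavy atoms (2 carbon, 3 nitrogen; no ring) in place of a group of 4 heavy atoms (1 carbon, 3 nitrogen; no ring), on a saturated chain carbon, three bonds along the chain from a carbonyl carbon. The change sits on a saturated chain carbon, three bonds along the chain from a carbonyl carbon, and keeps the same counts of donors, acceptors and charge.

Going by the values given here, with no comparable step recorded, the size of the step in this assay is uncertain. A small rise is expected, of roughly the size of the scatter or a little beyond it; a fall is not ruled out. The estimate for compound 4 is 30%, within 5% to 65%, which means an expected step of a number 11.7 percentage points higher from compound 3 to compound 4 (beyond the scatter).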

Compound 4, a percentage reported as inhibition, at one concentration (the size of the read-out at that concentration, not a potency): 65.9%
Estimate against measurement, compound 4: 35.9 percentage points below, outside the stated range (above it).
By their numbers in this assay, from the lowest: compound 3; then compound 4; then compound 2; then compound 1.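

In this assay, the saturated chain carbon three bonds along the chain from a carbonyl carbon proves a sensitive place: a group of 5 heavy atoms (2 carbon, 3 nitrogen; no ring) in place of a group of 4 heavy atoms (1 carbon, 3 nitrogen; no ring) gives a number 47.6 percentage points higher from compound 3 to compound 4 (beyond the scatter), a large step. For the compounds shown here, this is the first single-place step, and it arises with the same counts of hydrogen-bond donors and acceptors and no net charge on either group. Nothing at hand accounts for the size of this step.

From the compounds shown here alone, one step fixes no trend, so whether a longer chain would raise the number further or lower it stays open. Also open, going by these compounds, is whether an amine in place of the nitrogen-rich end of the group would keep any of the step.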